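Removing an Aromatic Methyl from Compound 2

This account rests on a few compounds, and the source may have more. Where it says the series, first, only, none or still open, it means among the compounds named here.

In an ADME assay on Vero cells (Chlorocebus sabaeus) for cytotoxicity (on this read-out lower numbers stand for higher toxicity in this test and higher numbers for lower toxicity in this test), three compounds with a shared core have been measured. Compound 1 (`O=C1C(=O)N(Cc2cn(CC(=O)N3CCN(c4cc5c(cc4F)c(=O)c(C(=O)O)cn5C4CC4)CC3)nn2)c2c(F)cccc21`) gives 8 ug/mL, compound 2 (`CCO/N=C1/C(=O)N(Cc2cn(CC(=O)N3CCN(c4cc5c(cc4F)c(=O)c(C(=O)O)cn5C4CC4)CC3)nn2)c2ccc(C)cc21`) gives 32 ug/mL, and compound 3 (`CO/N=C1/C(=O)N(Cc2cn(CC(=O)N3CCN(c4cc5c(cc4F)c(=O)c(C(=O)O)cn5C4CC4)CC3)nn2)c2ccc(C)cc21`) gives 8 ug/mL. Compound 2 thus has the highest number of the three, beyond the scatter from each of the others. Compound 4 (`CCO/N=C1/C(=O)N(Cc2cn(CC(=O)N3CCN(c4cc5c(cc4F)c(=O)c(C(=O)O)cn5C4CC4)CC3)nn2)c2ccccc21`) is compound 2 with hydrogen in place of methyl on an aromatic carbon. Among the compounds with values here, no measured step makes this exact change, and compound 1 differs from compound 2 in more than one place. The closest guide is a swap of hydrogen for methyl elsewhere, on a saturated chain carbon bound to an oxygen on an unsaturated carbon, which gives a 4.0-fold lower number from compound 2 to compound 3 (0.60 log units; beyond the scatter). On that single modest step, a somewhat smaller move toward a lower number is expected in this assay. The estimated step is a 2.0-fold lower number from compound 2 to compound 4 (0.30 log units; within the scatter). For compound 4 the expected value is 16 ug/mL, with an estimated range from 6 ug/mL to 50 ug/mL.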

Compound 4, half-maximal cytotoxic concentration: 64 ug/mL
Compound 4: the middle estimate sits 4.0-fold (0.60 log units) below what was measured; the whole stated range lies below it.
By their numbers in this assay, from the lowest: compounds 1 and 3 (each within the scatter of the next); then compounds 2 and 4 (each within the scatter of the next).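

In this assay, the aromatic methyl of compound 2 proves dispensable: hydrogen in its place gives a 2.0-fold higher number from compound 2 to compound 4 (0.30 log units; within the scatter), so this position shows no change beyond the scatter. Within the data shown here, the only earlier single-place step, a 4.0-fold lower number from compound 2 to compound 3 (0.60 log units; beyond the scatter), concerned the saturated chain carbon bound to an oxygen and lay beyond the scatter, so the read-out does not respond to every removal of a methyl in the same way. Nothing available explains why this aromatic carbon accepts the swap.

The compounds shown leave open whether a larger or differently built group on this aromatic carbon, such as a chlorine, a methoxy or an amine, would shift the number beyond the scatter. They also leave open whether the same swap would hold with the shorter chain of compound 3.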